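A New Aryl Group on the Ring Nitrogen

This account rests on a few compounds, and the source may have more. Where it says the series, first, only, none or still open, it means among the compounds named here.

Measured so far, all in a functional assay on PC-12 cells (Rattus norvegicus) for cytotoxicity, read by MTT assay, with stated times of 2 h and 24 h, tested at 10 uM; on this read-out lower numbers stand for a weaker effect and higher numbers for a stronger effect at the one concentration tested:
compound 1 `Cc1ccc(-n2nc(-c3ccc(C(F)(F)F)cc3O)nc2-c2ccccc2O)cc1` gives 102%
compound 2 `CC(C)(C)c1ccc(-n2nc(-c3ccc(C(F)(F)F)cc3O)nc2-c2ccccc2O)cc1` gives 81.1%
compound 3 `Oc1cc(C(F)(F)F)ccc1-c1nc(-c2ccccc2O)n(-c2ccc(OC(F)(F)F)cc2)n1` gives 92.5%

Compound 3 holds the second highest of the three numbers, though the gap to compound 1 lies within the scatter, so the two cannot be told apart; compound 2 lies further off, as a number 11.4 percentage points higher from compound 2 to compound 3 (beyond the scatter) shows. Compound 4 `Oc1cc(C(F)(F)F)ccc1-c1nc(-c2ccccc2O)n(-c2cccc(C(F)(F)F)c2)n1` has not been measured. It differs from compound 3 in one place: 3-(trifluoromethyl)phenyl in place of 4-(trifluoromethoxy)phenyl on an aromatic nitrogen. Going by the values given here, three measured steps bear on this, since each changed a group on the same aryl ring: a number 9.5 percentage points lower from compound 1 to compound 3 (within the scatter), a number 11.4 percentage points higher from compound 2 to compound 3 (beyond the scatter) and a number 20.9 percentage points lower from compound 1 to compound 2 (beyond the scatter). Each replaced one group on an aromatic carbon; none exchanged 4-(trifluoromethoxy)phenyl for 3-(trifluoromethyl)phenyl, so no direct guide exists. Every step was modest at most. Compound 4 is therefore expected to sit near compound 3, with a number 2.5 percentage points lower from compound 3 to compound 4 (within the scatter) expected to stay within the scatter. The estimate for compound 4 in this assay is 90%, ranging from 75% to 105%.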

Compound 4, a percentage reported as activity, at one concentration (the size of the read-out at that concentration, not a potency): 99.9%
Compound 4: middle estimate off by 9.9 percentage points, on the low side, and the stated range covers the measured number.
By their numbers in this assay, from the lowest: compound 2; then compounds 3, 4 and 1 (each within the scatter of the next).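

In this assay, 3-(trifluoromethyl)phenyl on the aromatic nitrogen cannot be told apart from 4-(trifluoromethoxy)phenyl, with a number 7.4 percentage points higher from compound 3 to compound 4 (within the scatter), or from 4-methylphenyl, with a number 2.1 percentage points lower from compound 1 to compound 4 (within the scatter), so this new aryl group brings no change that the read-out can resolve. Among the four compounds, only 4-(tert-butyl)phenyl stands apart, with a number 18.8 percentage points higher from compound 2 to compound 4 (beyond the scatter), which leaves compound 2 with the lowest number, beyond the scatter from each of the others. Nothing available explains why these groups give the numbers they do.

The step from compound 3 to compound 4 changes both the group and where it sits on the phenyl ring, so the two changes cannot be separated. On these data alone, how a phenyl ring carrying an amine or a carboxylic acid would behave at this nitrogen also remains open.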